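The source may hold more compounds than are shown below. What is called first, only, known or untested is meant among the compounds shown, and "the series" means these compounds.

Compound 1 `Cc1ccccc1OCC(=O)N/N=C/c1ccc[nH]1` and compound 3 `Cc1cc(Cl)ccc1OCC(=O)N/N=C/c1ccc[nH]1` share one core. In a functional assay (Homo sapiens) for inhibition (on this read-out lower numbers stand for an effect already at smaller amounts and higher numbers for an effect only at larger amounts of compound), compound 1 gives 40700 nM and compound 3 gives 2890 nM. The change between them, (chloro in place of hydrogen on an aromatic carbon), made the step of a 14-fold lower number from compound 1 to compound 3 (1.15 log units; beyond the scatter). Compound 2 `O=C(COc1c(Cl)cccc1Cl)N/N=C/c1ccc[nH]1` rests on a different core; how the two cores differ is not broken down here. In this assay compound 2 gives 126000 nM, the highest of the three numbers, standing beyond the scatter against compound 1 and compound 3 alike.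

Compound 4 `O=C(COc1c(Cl)cc(Cl)cc1Cl)N/N=C/c1ccc[nH]1` has not yet been measured. It differs from compound 2 by chloro in place of hydrogen on an aromatic carbon, the same kind of change as from compound 1 to compound 3, though not the same: here the entering chloro is meta to two chloro groups, there it was meta to a methyl group. For compound 4 in this assay the step of an 8.4-fold lower number from compound 2 to compound 4 (0.92 log units; beyond the scatter) is expected; this expectation rests on a 14-fold lower number from compound 1 to compound 3 (1.15 log units; beyond the scatter), with the differing surroundings of the place leaving room for a smaller move. Compound 4 is accordingly estimated at 15000 nM, with the likely span running from 4000 nM to 60000 nM.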

Compound 4, half-maximal effective concentration: 1160 nM
The estimate for compound 4 lay 13-fold (1.11 log units) above the measured number; measured number below the stated range.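

In this assay chloro in place of hydrogen on an aromatic carbon lowers the number again (a 110-fold lower number from compound 2 to compound 4 (2.04 log units; beyond the scatter)), so the direction of the step holds on both cores, but its size does not: the same change on two cores in this assay, a 14-fold lower number (1.15 log units; beyond the scatter) from compound 1 to compound 3 and a 110-fold lower number (2.04 log units; beyond the scatter) from compound 2 to compound 4, 7.7-fold (0.89 log units) apart, beyond the scatter of two such steps. For this series, the change therefore cannot be carried from one core to another as a fixed increment, and only its direction is shared by the two pairs. With just two pairs, the data do not show what sets the size of the step, since the entering chloro is meta to two chloro groups in compound 4 and the cores differ in more than one place, nor do they show that the direction would hold on a third core.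

Still open, from the compounds shown here alone, is whether bromo, methoxy or an amine at this same place, para to a large group, would give a step like that of chloro. Also open, going by these compounds, is whether the step would persist with a longer chain in place of the link joining the aromatic ring to the hydrazone end.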